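The source may hold more compounds than are shown below. What is called first, only, known or untested is meant among the compounds shown, and "the series" means these compounds.

Measured so far:
- compound 1 `CCCCCCCCCCCCCCNC(=O)[C@H](CO)/N=C/c1cccc(C)c1` gives 51100 nM
- compound 2 `CCCCCCCCCCCCCCNC(=O)[C@H](CO)/N=C/c1cccc(OC)c1` gives 77300 nM

In an ADME assay on HEK293 cells (Homo sapiens) for cytotoxicity (on this read-out higher numbers stand for weaker inhibition and lower numbers for stronger inhibition), compound 2 gives 77300 nM and stands within the scatter of compound 1. Compound 3 `CCCCCCCCCCCCCCNC(=O)[C@H](CO)/N=C/c1ccc(OC)cc1` differs from compound 2 by 4-methoxyphenyl in place of 3-methoxyphenyl on a carbon with a double bond to nitrogen with 4-methoxyphenyl in place of 3-methoxyphenyl on a carbon with a double bond to nitrogen. Within the data shown here, the only measured step is a 1.5-fold higher number from compound 1 to compound 2 (0.18 log units; within the scatter) for methoxy in place of methyl on an aromatic carbon. That step exchanges one group for another rather than moving one, so it bears only loosely on this change, and no shift beyond the scatter is expected. The expected size is a 1.2-fold lower number from compound 2 to compound 3 (0.08 log units; within the scatter) in this estimate. For compound 3 the estimated value is 65000 nM with an expected range from 28000 nM to 150000 nM in this read-out.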

Compound 3, half-maximal inhibitory concentration: 81700 nM
For compound 3 the middle estimate is 1.3-fold (0.10 log units) below the measured one, and the stated range covers the measured number.
By their numbers in this assay, from the lowest: compounds 1, 2 and 3 (each within the scatter of the next).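

In this assay, 4-methoxyphenyl in place of 3-methoxyphenyl on a carbon with a double bond to nitrogen gives a 1.1-fold higher number from compound 2 to compound 3 (0.02 log units; within the scatter), so these two placings of the methoxy group cannot be told apart. 4-Methoxyphenyl in place of 3-methylphenyl at the same carbon gives a 1.6-fold higher number from compound 1 to compound 3 (0.20 log units; within the scatter), so that exchange cannot be told apart either. No evidence is available that explains these results.

The compounds shown leave open whether an amine or a carboxylic acid on the aromatic ring would shift the number beyond the scatter. They also leave open what a longer chain would do.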